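The compounds below may be only part of what the source reports. "The series", "measured", "known", "first", "only" and "open" are said of these compounds alone.

Compound 3 `N#Cc1c(Nc2cccc(Cl)c2)nc(SCc2cn(Cc3ccccc3Cl)nn2)nc1-c1ccccc1` belongs to a small set tested in a functional assay on MGC-803 cells (Homo sapiens) for inhibition, read by MTT assay, with a stated time of 72 h (a higher number here means a weaker inhibitor, a lower number a stronger inhibitor), where compound 3 gives 15800 nM. Compound 1 `C#CCSc1nc(Nc2ccccc2Cl)c(C#N)c(-c2ccccc2)n1` gives 52800 nM in this assay, a higher number than compound 3. Compound 2 `C#CCSc1nc(Nc2cccc(Cl)c2)c(C#N)c(-c2ccccc2)n1` reaches only a limit of the assay, > 128000 nM. Among the compounds with values here, the one measured step, an at least 2.4-fold higher number from compound 1 to compound 2 (0.38 log units; beyond the scatter), concerns where the chlorine sits on the aniline ring, with the limit of > 128000 nM in this assay, at which 1 of the 3 values shown sits, bounding it. Compound 4 `N#Cc1c(Nc2cccc([N+](=O)[O-])c2)nc(SCc2cn(Cc3ccccc3Cl)nn2)nc1-c1ccccc1` keeps the core of compound 3 and changes the aniline substituent: nitro in place of chloro on an aromatic carbon. Within the data shown here, no measured step covers a chloro-to-nitro exchange, so the expected step of a 1.1-fold lower number from compound 3 to compound 4 (0.05 log units; within the scatter) is small and uncertain. Compound 4 is therefore estimated at 14000 nM in this assay, between 5000 nM and 40000 nM.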

Compound 4, half-maximal inhibitory concentration: 43100 nM
Beside the measured number, compound 4's estimate is 3.1-fold (0.49 log units) below it; measured number above the stated range.
By their numbers in this assay, from the lowest: compound 3; then compounds 4 and 1 (each within the scatter of the next). At a limit, above all of these: compound 2.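

Earlier, only the place of the chlorine on the aniline ring changed; here the place stays and the group itself changes, and in this assay nitro in place of chloro gives a 2.7-fold higher number from compound 3 to compound 4 (0.44 log units; beyond the scatter). So the identity of the group at this position counts too, not only where it sits on the ring. Nothing measured here accounts for this modest step.

Going by these compounds, whether an amine or a methoxy group at the same place would give a lower or a higher number remains open. So does whether nitro in place of chloro would act the same way on the core of compound 2.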